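Methoxy removal on the pendant phenyl of two indole vinyl series

This account rests on a few compounds, and the source may have more. Where it says the series, first, only, none or still open, it means among the compounds named here.

Measured compounds in a functional assay on MDA-MB-231 cells (Homo sapiens) for inhibition, read by sulforhodamine B assay, with a stated time of 48 h; on this read-out higher numbers stand for weaker inhibition of growth and lower numbers for stronger inhibition of growth:
- compound 1 `COc1ccc2[nH]c(-c3ccccc3)c(C=C(C#N)C#N)c2c1`: 3800 nM
- compound 2 `COc1ccc(-c2[nH]c3ccc(OC)cc3c2/C=C(\C#N)S(=O)(=O)c2ccccc2)cc1`: 1400 nM
- compound 3 `COc1ccc(-c2[nH]c3ccc(OC)cc3c2C=C(C#N)C#N)cc1`: 1300 nM

Compound 3 and compound 2 share the same indole part and differ in the group attached to the exocyclic double bond; the difference between the two cores is not broken down here. In this assay compound 3 gives 1300 nM and compound 2 gives 1400 nM, and the two values lie within the scatter of each other, so no order between them can be read.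

For the measured compounds named here, the one step measured within the set is hydrogen in place of methoxy on an aromatic carbon; it gives a 2.9-fold higher number from compound 3 to compound 1 (0.47 log units; beyond the scatter). The same change, (hydrogen in place of methoxy on an aromatic carbon), takes compound 2 to compound 4 `COc1ccc2[nH]c(-c3ccccc3)c(/C=C(\C#N)S(=O)(=O)c3ccccc3)c2c1`, which has not yet been measured in this assay. The place of the change is the same in both pairs, so the two changes are the same change, made on two different cores.

Going by the values given here, only one instance of this change has a measured outcome, and nothing here shows whether the two cores respond alike. Among the compounds with values here, with that caveat, the step from compound 2 to compound 4 is expected to be a 2.9-fold higher number from compound 2 to compound 4 (0.46 log units; beyond the scatter), resting on the measured 2.9-fold higher number from compound 3 to compound 1 (0.47 log units; beyond the scatter) as the only precedent. Within the data shown here, on that basis compound 4 is estimated to give 4000 nM in this assay, with a range from 1500 nM to 11000 nM to allow for the single precedent and for scatter.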

Compound 4, concentration for 50% growth inhibition: 7500 nM
Beside the measured number, compound 4's estimate is 1.9-fold (0.27 log units) below it; the measured number falls inside the stated range.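

In this assay, hydrogen in place of methoxy on the core of compound 2 gives a 5.4-fold higher number from compound 2 to compound 4 (0.73 log units; beyond the scatter). Both measured instances of 4-methoxyphenyl to phenyl now run the same way, and their sizes cannot be told apart: the same change on two cores in this assay, a 2.9-fold higher number (0.47 log units; beyond the scatter) from compound 3 to compound 1 and a 5.4-fold higher number (0.73 log units; beyond the scatter) from compound 2 to compound 4, 1.8-fold (0.26 log units) apart, within the scatter of two such steps. This supports carrying the change between these two cores as a shift in the same direction with a similar size, but two pairs in a single cell line set no rule for any further core and give no cause for the shift.

The compounds shown cover only methoxy and hydrogen at this place on the pendant phenyl, so it remains open how a hydroxyl, an amine, a fluorine or a longer ether such as ethoxy would compare there. Also open, from the compounds shown here alone, is whether the same step holds with groups other than the two nitriles and the nitrile with phenylsulfonyl on the exocyclic double bond, for instance a carboxylic acid or an amide in place of a nitrile.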